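Fluorine on the phenyl ring of compound 2

The compounds below may be only part of what the source reports. "The series", "measured", "known", "first", "only" and "open" are said of these compounds alone.

Of the compounds shown here, three of the same core have been measured in a functional assay, tested at 400 ug/mL; a lower number here means a weaker effect, a higher number a stronger effect of the compound at the concentration tested. Compound 1 `N#CC1=C(N)OC(c2c[nH]c3ccccc23)=C(C#N)C1c1cccc2ccccc12` gives 10.4%, compound 2 `N#CC1=C(N)OC(c2c[nH]c3ccccc23)=C(C#N)C1c1ccccc1` gives 26.7%, and compound 3 `N#CC1=C(N)OC(c2c[nH]c3ccccc23)=C(C#N)C1c1ccc2ccccc2c1` is reported as "not active" (no number reported). Compound 2 holds the higher of the two numbers; the step of a number 16.3 percentage points higher from compound 1 to compound 2 (beyond the scatter) is modest. Compound 4 `N#CC1=C(N)OC(c2c[nH]c3ccccc23)=C(C#N)C1c1ccccc1F` differs from compound 2 by fluoro in place of hydrogen on an aromatic carbon. Within the data shown here, no measured step changes a single substituent on this ring, so nothing among the measured steps bears directly on this change; the only aryl step was the modest one from compound 1 to compound 2. Compound 4 is therefore expected to stay near compound 2, with a step of about a number 0.3 percentage points higher from compound 2 to compound 4 (within the scatter) that lies within the scatter. The estimate for compound 4 is 27%, ranging from 12% to 42%.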

Compound 4, a percentage reported as activity, at one concentration (the size of the read-out at that concentration, not a potency): "not active" (no number reported)
No number was reported for compound 4; no gap can be computed for the estimate.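

Among these compounds, compound 4 is reported as "not active" with no number, so no step from compound 2 can be read in this assay. The compounds shown leave open whether any other substituent on that phenyl ring would give a number. Nothing shown offers an explanation for this result.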